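Acetylating the Amine of Compound 2: An Open Question

A few compounds are considered here, and "the series" means these few. Any claim that something is new, unique, unknown or untested is made for them only; others in the source may bear on it.

Compound 2 `COC(=O)C1=C(C)OC(N)=C(C(=O)OC(C)C)C1c1cccc([N+](=O)[O-])c1` was measured in an assay on HEK293 cells for antagonist activity at Voltage-dependent L-type calcium channel subunit alpha-1D (Rattus norvegicus), read by FLIPR (a lower number here means a stronger inhibitor, a higher number a weaker inhibitor), where compound 2 gives 1820 nM. Compound 1 `CCOC(=O)C1=C(N)OC(C)=C(C(=O)OC)C1c1cccc([N+](=O)[O-])c1` is its only measured companion; in this assay compound 1 gives 2720 nM. Going by the values given here, the one step connecting them, a 1.5-fold lower number from compound 1 to compound 2 (0.17 log units; within the scatter), concerns methyl in place of hydrogen on a saturated chain carbon bound to an oxygen next to a carbonyl group and a saturated chain carbon. Compound 2 stands at the lower of the two numbers, a gap that lies within the scatter. Compound 3 `COC(=O)C1=C(C)OC(NC(C)=O)=C(C(=O)OC(C)C)C1c1cccc([N+](=O)[O-])c1` differs from compound 2 by acetyl in place of hydrogen on an amine nitrogen, amino to acetamido. Among the compounds with values here, no measured step touches the amine nitrogen, so the pair offers no guide to this change and the expectation is uncertain. Compound 3 is estimated at 3000 nM, with a range from 800 nM to 12000 nM. The step of a 1.6-fold higher number from compound 2 to compound 3 (0.22 log units; within the scatter) is expected to be modest, tending toward weaker inhibition, if any.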

Compound 3, half-maximal inhibitory concentration: 13600 nM
For compound 3 the middle estimate is 4.5-fold (0.66 log units) below the measured one; measured number above the stated range.
By their numbers in this assay, from the lowest: compounds 2 and 1 (each within the scatter of the next); then compound 3.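

In this assay, going by these compounds alone, the amine nitrogen proves to be a position where the number responds: acetyl in place of hydrogen gives a 7.5-fold higher number from compound 2 to compound 3 (0.87 log units; beyond the scatter) and this step lies beyond the scatter, whereas the only earlier step, a 1.5-fold lower number from compound 1 to compound 2 (0.17 log units; within the scatter) and so within it, left the amine untouched. On this one pair, the amino form of compound 2 is therefore the stronger inhibitor and the acetamido form of compound 3 the weaker. No measurement shown here accounts for this loss.

Going by these compounds, whether the loss belongs to acetyl alone or extends to other groups on this nitrogen remains open, and a methyl group, a longer acyl chain such as propionyl, or a methanesulfonyl group would help to tell. Also open, on these data alone, is whether acetyl has the same effect on the core of compound 1.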